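A few compounds are considered here, and "the series" means these few. Any claim that something is new, unique, unknown or untested is made for them only; others in the source may bear on it.

Measured so far
- Compound 1, `CC(C)(CCCOc1ccc(/C=C/c2ccccc2)cc1)C(=O)O`, in a physicochemical assay for solubility, read by spectrophotometry, in simulated intestinal fluid, at pH 6.5 (on this read-out higher numbers stand for higher solubility and lower numbers for lower solubility), gives 8.7 ug/mL.
- Compound 2, `CC(C)(Oc1ccc(CCCOc2ccc(/C=C/c3ccccc3)cc2)cc1)C(=O)O`, in this assay gives 24.8 ug/mL.

Compound 2 stands highest of the two numbers; its nearest neighbour is compound 1, whose number is lower by a margin beyond the usual scatter. For the measured compounds named here, no step between measured compounds that differ in one place is available, so the move to compound 3 rests on the structural change alone.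

Compound 3, `CC(C)(Oc1ccc(CCCOc2ccc(C(=O)/C=C/c3ccccc3)cc2)cc1)C(=O)O`, differs from compound 2 in one place: (2-phenylethenyl)carbonyl in place of 2-phenylethenyl on an aromatic carbon. The change sits on an aromatic carbon of a six-membered aromatic ring of carbon only, para to a large group.

Going by the values given here, with no matched step to lean on, the expected step from compound 2 to compound 3 in this assay is a 1.4-fold higher number from compound 2 to compound 3 (0.15 log units; within the scatter), upward but small, and possibly not beyond the scatter. Compound 3 is estimated at 35 ug/mL, within a range of 14 ug/mL to 85 ug/mL.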

Compound 3, solubility: 19.6 ug/mL
The estimate for compound 3 lay 1.8-fold (0.25 log units) above the measured number; the range from low to high includes it.
By their numbers in this assay, from the lowest: compound 1; then compounds 3 and 2 (each within the scatter of the next).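

In this assay, (2-phenylethenyl)carbonyl in place of 2-phenylethenyl on an aromatic carbon, para to a large group, gives a 1.3-fold lower number from compound 2 to compound 3 (0.10 log units; within the scatter). For the compounds shown here, this is the first step that can be read at one place, and on this read-out it does not separate the two groups, even though the entering group adds one carbonyl and one hydrogen-bond acceptor by count. No supporting measurement bears on this result, so the step stands without an explanation.

Still open, going by these compounds, is whether a different group at this aromatic carbon, such as an amine or a carboxylic acid, would give a step beyond the scatter. A single step also leaves open whether the same change on the core of compound 1 would read the same way.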